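Adding a Second Methyl to the Aryl Ring of Compound 1

The source may report more compounds than this note shows. Statements on the series, on what has been measured and on what is new or still open speak of the compounds shown alone.

Compound 1 `Cc1ccccc1-n1nncc1CN1C(=O)C2(C(C#N)=C(N)Oc3c2c2nc4ccccc4nc2c2ccccc32)c2ccccc21` stands at the limit of a functional assay on HepG2 cells (Homo sapiens) for antiproliferative activity, read by MTT assay, with a stated time of 48 h; on this read-out lower numbers stand for stronger inhibition and higher numbers for weaker inhibition: in this assay compound 1 gives > 50000 nM, which is a limit rather than a number. Compound 2 `COc1ccc(-n2nncc2CN2C(=O)C3(C(C#N)=C(N)Oc4c3c3nc5ccccc5nc3c3ccccc43)c3ccccc32)cc1` likewise gives > 50000 nM, again a limit. Compound 3 `N#CC1=C(N)Oc2c(c3nc4ccccc4nc3c3ccccc23)C12C(=O)N(Cc1cnnn1-c1cccc(S(N)(=O)=O)c1)c1ccccc12` gives 21500 nM. The step that the two limits leave unreadable from compound 1 to compound 2 cannot be read, while an at least 2.3-fold lower number from compound 1 to compound 3 (0.36 log units; beyond the scatter) and an at least 2.3-fold lower number from compound 2 to compound 3 (0.36 log units; beyond the scatter) are at least modest. Compound 4 `Cc1ccc(-n2nncc2CN2C(=O)C3(C(C#N)=C(N)Oc4c3c3nc5ccccc5nc3c3ccccc43)c3ccccc32)c(C)c1` differs from compound 1 by methyl in place of hydrogen on an aromatic carbon. Among the compounds with values here, no measured step adds a methyl on this ring, and the two values at the limit of > 50000 nM in this assay, at which 2 of the 3 values shown sit, show only that compound 1 and compound 2 are each reported as a limit. Compound 4 is therefore expected to remain near that limit, a step that the limit leaves unreadable from compound 1 to compound 4 without readable size, with an estimate of 60000 nM (range 20000 nM to 200000 nM).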

Compound 4, half-maximal inhibitory concentration: > 50000 nM
Compound 4 gave a limit, no number; the forecaster's own chance of this, stated with the estimate: 70%; the middle value lies beyond the limit too.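

In this assay, going by these compounds, compound 4 gives > 50000 nM, which is a limit and not a number, so the steps joining it to compound 1 and compound 2 cannot be read and the size of any effect of the added methyl stays unknown. Exchanging 3-sulfamoylphenyl for 2,4-dimethylphenyl gives an at least 2.3-fold higher number from compound 3 to compound 4 (0.36 log units; beyond the scatter). Within the data shown here, compound 3 thus remains the only compound with a number, and the new methyl adds one more compound to those at the ceiling: the limit of > 50000 nM in this assay, at which 3 of the 4 values shown sit. Open, on these data alone, is whether a methyl at this place would change the value on the 3-sulfamoylphenyl ring, where a number can be read. Also open, as far as these compounds go, is what an amine or a carboxylic acid on the aryl ring would give.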